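Nitro for Chloro on the Aryl Hydrazide

The source may hold more compounds than are shown below. What is called first, only, known or untested is meant among the compounds shown, and "the series" means these compounds.

Three hydrazides have been measured in a functional assay for inhibition, read by spectrophotometry, with a stated time of 120 min; a lower number here means a stronger inhibitor, a higher number a weaker inhibitor. Compound 1 `CCOC(=O)N1CCC(=NNC(=O)c2ccc(Cl)cc2)CC1` gives 72300 nM, and its fluoro analogue, compound 2 `CCOC(=O)N1CCC(=NNC(=O)c2ccc(F)cc2)CC1`, gives 65600 nM; the step of a 1.1-fold lower number from compound 1 to compound 2 (0.04 log units; within the scatter) shows that exchanging one halogen for another leaves the number where it was. Compound 3 `O=C(NN=C1CC(c2ccccc2)NC(c2ccccc2)C1)c1ccc(Cl)cc1`, which carries the same 4-chlorophenyl hydrazide on a different core, gives 43600 nM. Its number is the smallest of the three, but the gaps to compound 2 and to compound 1 lie within the scatter, so the three compounds are not separated by this assay.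

Compound 4 `O=C(NN=C1CC(c2ccccc2)NC(c2ccccc2)C1)c1ccc([N+](=O)[O-])cc1` keeps the core of compound 3 and differs by nitro in place of chloro on an aromatic carbon. For the measured compounds named here, the only measured step that touches the same ring position, from compound 1 to compound 2, was a halogen-for-halogen swap and stayed within the scatter; no measured pair shows what a nitro group does here. On that basis no step beyond the scatter is expected, and the estimated step is a 1.1-fold lower number from compound 3 to compound 4 (0.04 log units; within the scatter), with a wide range to cover the unknown. Compound 4 is therefore expected to give about 40000 nM in this assay, between 14000 nM and 115000 nM.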

Compound 4, half-maximal inhibitory concentration: 45200 nM
Estimate against measurement, compound 4: 1.1-fold (0.05 log units) below; the range from low to high includes it.
By their numbers in this assay, from the lowest: compounds 3, 4, 2 and 1 (each within the scatter of the next).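

The change from 4-chlorophenyl to 4-nitrophenyl gives, in this assay, a 1.0-fold higher number from compound 3 to compound 4 (0.02 log units; within the scatter). Until now this position had been probed only by a halogen-for-halogen exchange, whereas here 1 chlorine gives way to 3 heavy atoms with 2 hydrogen-bond acceptors, and the step still stays within the scatter, as does a 1.1-fold lower number from compound 1 to compound 2 (0.04 log units; within the scatter) on the other core. For the compounds shown, then, neither change on this aromatic carbon separates a pair, and this holds on each of the two cores, though each change has been read on one core only; no accompanying measurement offers any explanation for this.

As far as these compounds go, it remains open whether nitro in place of chloro would also stay within the scatter on the core of compound 1, and whether any replacement on this ring can move the number beyond the scatter, for example an amine, a carboxylic acid or a longer chain. Also open, from the compounds shown here alone, is how much the core itself contributes, as the compounds on the two cores differ in more than one place and cannot be compared directly.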